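A few compounds are considered here, and "the series" means these few. Any claim that something is new, unique, unknown or untested is made for them only; others in the source may bear on it.

Within the data shown here, in an ADME assay on Vero 76 cells (Chlorocebus sabaeus) for cytotoxicity, read by MTT assay, with a stated time of 96 h (on this read-out lower numbers stand for higher toxicity in this test and higher numbers for lower toxicity in this test), three compounds sharing one core have numbers so far. Compound 1 (`NS(=O)(=O)c1ccc(N2N=C(c3ccc(OCc4ccccc4)cc3)CC2c2ccc(F)cc2)cc1`) gives 90000 nM, compound 2 (`Cc1cccc(C2CC(c3ccc(Oc4ccccc4)cc3)=NN2c2ccc(S(N)(=O)=O)cc2)c1`) gives 81000 nM, and compound 3 (`Cc1cccc(C2CC(c3ccccc3)=NN2c2ccc(S(N)(=O)=O)cc2)c1`) gives 25000 nM, the lowest of the three. Compound 4 (`Cc1cccc(C2CC(c3ccc(OCc4ccccc4)cc3)=NN2c2ccc(S(N)(=O)=O)cc2)c1`) has not been measured yet and differs from compound 3 in one place: benzyloxy in place of hydrogen on an aromatic carbon. In words, benzyloxy stands in place of hydrogen on an aromatic carbon, para to a large group.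

The closest guide is a 3.2-fold lower number from compound 2 to compound 3 (0.51 log units; beyond the scatter), a modest change beyond the scatter, in which hydrogen replaced phenoxy. Compound 4 goes the opposite way, adding a group instead of removing one, so a rise of similar size seems reasonable. Compound 1 also carries benzyloxy and gives 90000 nM, although it differs elsewhere in its structure. Among the measured compounds shown here, this is thin evidence, resting on only two compounds. The expected change is a 3.0-fold higher number from compound 3 to compound 4 (0.48 log units; beyond the scatter), toward a higher number in this assay. For compound 4 the estimated value is 75000 nM, with an expected range from 40000 nM to 110000 nM.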

Compound 4, half-maximal cytotoxic concentration: 100000 nM
Estimate against measurement, compound 4: 1.3-fold (0.12 log units) below; low and high end bracket the measured number.
By their numbers in this assay, from the lowest: compound 3; then compounds 2, 1 and 4 (each within the scatter of the next).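

In this assay, among these compounds, benzyloxy in place of hydrogen on this aromatic carbon gives a 4.0-fold higher number from compound 3 to compound 4 (0.60 log units; beyond the scatter), a clear rise that the earlier compounds could only suggest through phenoxy. Changing the group on the oxygen gives only a 1.2-fold higher number from compound 2 to compound 4 (0.09 log units; within the scatter), and changing the group on the saturated ring carbon gives a 1.1-fold higher number from compound 1 to compound 4 (0.05 log units; within the scatter); both steps lie within the scatter, so in these compounds neither swap shows a change. No measured evidence is available to explain the rise from hydrogen to benzyloxy.

The compounds shown do not tell whether the added aromatic ring is needed, since a small group such as methoxy or hydroxyl at this position could test that. An amine or a carboxylic acid here also remains an open case.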